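Ester for acid at the terminal aryl ether

A few compounds are considered here, and "the series" means these few. Any claim that something is new, unique, unknown or untested is made for them only; others in the source may bear on it.

Measured so far:
compound 1 `Cc1c(OCCCCOc2cccc(C(=O)O)c2)ccc(C(=O)CC(C)C)c1C` — 18.3%
compound 2 `Cc1c(OCCCCOc2cccc(C(=O)O)c2)ccc(C(=O)CC(C)C)c1O` — 69.9%
compound 3 `Cc1c(OCCCCOc2cccc(C(=O)O)c2)ccc(C(=O)CC2CCCC2)c1C` — 16.5%

All three were run in an assay on HEK293 cells for positive allosteric modulation of metabotropic glutamate receptor 3 (Rattus norvegicus), read by thallium flux, with a stated time of 2.5 min; on this read-out lower numbers stand for smaller maximal responses and higher numbers for larger maximal responses. Compound 1 stands second highest of the three; its nearest neighbour is compound 3, which lies a number 1.8 percentage points lower from compound 1 to compound 3 (within the scatter), and its furthest is compound 2, which lies a number 51.6 percentage points higher from compound 1 to compound 2 (beyond the scatter).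

Compound 4 `COC(=O)c1ccc(OCCCCOc2ccc(C(=O)CC(C)C)c(C)c2C)cc1` has not been measured. It differs from compound 1 as follows: 4-(methoxycarbonyl)phenyl in place of 3-carboxyphenyl on an oxygen on a saturated carbon.

Of the two measured steps, neither touches this part of the molecule. The step to compound 2 changes a substituent on the aromatic ring of the shared core and was large; the step to compound 3 changes the saturated chain carbon bound to the carbonyl carbon and stayed within the scatter. Nothing measured here bears on the terminal aryl group, so the direction of the change to compound 4 is unsupported either way.

Compound 4 is therefore expected near compound 1, with a wide range: 25%, between 5% and 60%. The expected step is a number 6.7 percentage points higher from compound 1 to compound 4 (within the scatter).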

Compound 4, largest response reached (reported as percent of maximum), in percent of the reference or control that the assay uses: 27.3%
Beside the measured number, compound 4's estimate is 2.3 percentage points below it; measured number inside the range.
By their numbers in this assay, from the lowest: compounds 3, 1 and 4 (each within the scatter of the next, the first and the last beyond it); then compound 2.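

In this assay, for the compounds shown here, 4-(methoxycarbonyl)phenyl in place of 3-carboxyphenyl on an oxygen on a saturated carbon gives a number 9 percentage points higher from compound 1 to compound 4 (within the scatter), the first reading on this terminal aryl group, which neither earlier step touched. At this level of response, the free carboxylic acid of compound 1 is therefore not needed, even though the exchange takes the count from 1 hydrogen-bond donor to 0 and from 1 hydrogen-bond acceptor to 2. No supporting data bear on why the response holds here.

The two group names differ both in the function carried and in the number giving its place on the ring, so this single step cannot separate those two changes. Also open, on these data alone, is how a primary amide or a tetrazole would read on this terminal aryl group, and whether the methyl ester keeps its reading alongside the hydroxy of compound 2.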